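From Difluoromethyl to Trifluoromethyl in a Sodium Channel Series

The compounds below may be only part of what the source reports. "The series", "measured", "known", "first", "only" and "open" are said of these compounds alone.

Of the compounds shown here, three have so far been measured in an assay for inhibition of sodium channel protein type 9 subunit alpha (Mus musculus), read by patch clamp; a higher number here means a weaker inhibitor, a lower number a stronger inhibitor. Compound 1 `CC(C)COc1ccc(-c2cn(C)c3cc(C(=O)NS(=O)(=O)C4CC4)c(F)cc23)cn1` gives 24 nM. Compound 2 `Cn1cc(-c2ccc(C(F)F)cc2)c2cc(F)c(C(=O)NS(=O)(=O)C3CC3)cc21` gives 12 nM, and compound 3 `CC(C)COc1ncc(-c2nn(C)c3cc(C(=O)NS(C)(=O)=O)ccc23)cc1Cl` gives 12 nM. Compound 2 and compound 3 are level at the digits shown, and together they hold the lowest of the three numbers; the gap from compound 2 to compound 1 also lies within the scatter, so no order among the three can be read from these values.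

Compound 4 `Cn1cc(-c2ccc(C(F)(F)F)cc2)c2cc(F)c(C(=O)NS(=O)(=O)C3CC3)cc21` has not yet been measured in this assay. It differs from compound 2 in one place: fluoro in place of hydrogen on a saturated chain carbon bound to an aromatic carbon and two fluorine atoms. Cut one bond further out, the change reads difluoromethyl to trifluoromethyl, or 4-(difluoromethyl)phenyl to 4-(trifluoromethyl)phenyl. Among the measured compounds shown here, no measured pair in this set shows a step of this kind, so nothing in the data fixes its size or direction. Because compound 2 gives 12 nM, the expected step is no change at the digits printed from compound 2 to compound 4 (within the scatter), no larger than the scatter. Compound 4 is therefore expected to give 12 nM in this assay, with a range from 5 nM to 30 nM.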

Compound 4, half-maximal inhibitory concentration: 5 nM
Compound 4: middle estimate off by 2.4-fold (0.38 log units), on the high side; low and high end bracket the measured number.
By their numbers in this assay, from the lowest: compound 4; then compounds 2, 3 and 1 (each within the scatter of the next).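

In this assay, among the compounds shown here, the change from difluoromethyl to trifluoromethyl gives a 2.4-fold lower number from compound 2 to compound 4 (0.38 log units; beyond the scatter), the only step in this set and one that lies beyond the scatter. It shows that this position can respond measurably to a single added fluorine atom, with the number moving downward, towards stronger inhibition, although the step is modest and rests on one pair. No measurement at hand bears on why the number moves in this way.

The compounds shown leave open how this position would respond to other groups, such as methyl, a chlorine atom, nitrile or methoxy in place of trifluoromethyl. They also leave open whether the same change from difluoromethyl to trifluoromethyl would give a similar step on a different core.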